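The source may report more compounds than this note shows. Statements on the series, on what has been measured and on what is new or still open speak of the compounds shown alone.

For the measured compounds named here, in a functional assay on DU-145 cells (Homo sapiens) for cytotoxicity, read by MTT assay, with a stated time of 48 h (a lower number here means a stronger inhibitor, a higher number a weaker inhibitor), compound 1 (`O=C(COc1ccc(/C=C/C(=O)c2ccc(F)cc2)cc1)Nc1ccc2c(c1)COC2=O`) gives 6880 nM and compound 2 (`COc1ccc(/C=C/C(=O)c2ccc(OCC(=O)Nc3ccc4c(c3)COC4=O)cc2)cc1`) gives 2130 nM as the lower of the two numbers so far, a gap beyond the usual scatter. Compound 3 (`COc1cccc(/C=C/C(=O)c2ccc(OCC(=O)Nc3ccc4c(c3)COC4=O)cc2)c1`) differs from compound 2 by one change (3-methoxyphenyl in place of 4-methoxyphenyl on a double-bonded chain carbon bound to a double-bonded chain carbon): 3-methoxyphenyl in place of 4-methoxyphenyl on a double-bonded chain carbon bound to a double-bonded chain carbon. Going by the values given here, no measured pair shows this kind of change, so only a modest move is expected in this assay: the estimated 1.4-fold higher number from compound 2 to compound 3 (0.15 log units; within the scatter) is toward a slightly higher number and may stay within the scatter. Compound 3 is estimated at 3000 nM with an expected range from 1100 nM to 8000 nM for now.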

Compound 3, half-maximal inhibitory concentration: 2550 nM
Estimate against measurement, compound 3: 1.2-fold (0.07 log units) above, within the range that was stated.
By their numbers in this assay, from the lowest: compounds 2 and 3 (each within the scatter of the next); then compound 1.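

In this assay, 3-methoxyphenyl in place of 4-methoxyphenyl on a double-bonded chain carbon bound to a double-bonded chain carbon gives a 1.2-fold higher number from compound 2 to compound 3 (0.08 log units; within the scatter), so this assay does not tell these two placings of the methoxy group apart. No measurement at hand offers an explanation for this result. Still open, from the compounds shown here alone, is whether a hydroxyl, an amine or a carboxylic acid in place of the methoxy group would leave the number equally unmoved. Going by these compounds, compound 1 is linked to neither compound 2 nor compound 3 by a single change, so its place in this comparison also stays open.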